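Acetyl removal from compound 2: working notes

The source may hold more compounds than are shown below. What is called first, only, known or untested is meant among the compounds shown, and "the series" means these compounds.

compound 1 (`Cc1coc(-c2ccc3c(c2O)CCCC3(C)C)c1CO`) gives 21.3 uM
compound 2 (`COc1c(-c2occ(C)c2COC(C)=O)ccc2c1CCCC2(C)C`) gives 14 uM

Within the data shown here, both values come from a functional assay on SK-BR-3 cells (Homo sapiens) for cytotoxicity, read by sulforhodamine B assay, with a stated time of 3 days (a higher number here means that more compound is needed for the effect, a lower number that less compound is needed), and are the only numbers so far. Compound 2 stands within the usual scatter of compound 1, so the two cannot be ranked.

The next entry is compound 3 (`COc1c(-c2occ(C)c2CO)ccc2c1CCCC2(C)C`), which is not yet measured. It differs from compound 2 by hydrogen in place of acetyl on an oxygen on a saturated carbon, which reads as acetoxymethyl to hydroxymethyl. Among the measured compounds shown here, no measured pair shows this change alone, so the series gives no direct size for it.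

In this assay no step beyond the scatter is expected. The expectation rests on compound 2 at 14 uM and on compound 1 at 21.3 uM as the only anchors, and these two sit close together. The estimated step is a 1.3-fold higher number from compound 2 to compound 3 (0.11 log units; within the scatter) and stays within the scatter. The estimate for compound 3 is 18 uM with an expected range of 8 uM to 40 uM for the coming measurement.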

Compound 3, concentration for half-maximal effect: 23.7 uM
For compound 3 the middle estimate is 1.3-fold (0.12 log units) below the measured one, and the stated range covers the measured number.
By their numbers in this assay, from the lowest: compounds 2, 1 and 3 (each within the scatter of the next).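

In this assay, acetoxymethyl to hydroxymethyl now has a direct size (a 1.7-fold higher number from compound 2 to compound 3 (0.23 log units; within the scatter)), so hydrogen in place of acetyl on this oxygen on a saturated carbon does not separate the pair. The new compound also isolates a second change, methyl in place of hydrogen on an oxygen on an aromatic ring (a 1.1-fold higher number from compound 1 to compound 3 (0.05 log units; within the scatter)), and this pair is not separated either. Nothing given here bears on the reason for either result.

The compounds shown cover only hydrogen and acetyl on the oxygen on a saturated carbon and only hydrogen and methyl on the oxygen on an aromatic ring, so all three remain unranked and neither place has yet shown a step beyond the scatter. Going by these compounds, whether a larger change at either place would give such a step stays open, for example an amine or a carboxylic acid in place of the hydroxymethyl, or a longer chain in place of the methyl on the oxygen on an aromatic ring.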